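From a Benzyl Substituent to a Thiourea on the Ring Nitrogen

A few compounds are considered here, and "the series" means these few. Any claim that something is new, unique, unknown or untested is made for them only; others in the source may bear on it.

Measured compounds:
compound 1 `Cc1ccccc1CN1CCc2c(sc(NC(=O)c3ccccc3Cl)c2C(N)=O)C1` — > 50000 nM
compound 2 `NC(=O)c1c(NC(=O)c2ccccc2Cl)sc2c1CCN(C(=S)Nc1cccc3ccccc13)C2` — 13400 nM
compound 3 `NC(=O)c1c(NC(=O)c2ccccc2Cl)sc2c1CCN(C(=S)Nc1ccc(C(F)(F)F)cc1)C2` — 7590 nM

In a functional assay on HL-60 cells (Homo sapiens) for antiproliferative activity, with a stated time of 24 h (a higher number here means a weaker inhibitor, a lower number a stronger inhibitor), compound 1 reaches only a limit of the assay, > 50000 nM. Within the data shown here, it is the one compound of the three that sits there (the limit of > 50000 nM in this assay, at which 1 of the 3 values shown sits). Compounds 2 and 3 carry a thiourea on the same ring nitrogen of the shared core and give numbers in this assay: compound 2 gives 13400 nM and compound 3 gives 7590 nM. Among the measured compounds shown here, the one measured step between them, a 1.8-fold lower number from compound 2 to compound 3 (0.25 log units; within the scatter), shows that exchanging one aryl group on the thiourea for another moves the number little.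

Compound 4 `NC(=O)c1c(NC(=O)c2ccccc2Cl)sc2c1CCN(C(=S)Nc1c(Cl)cccc1Cl)C2` differs from compound 1 by a group of 11 heavy atoms (7 carbon, 1 nitrogen, 1 sulfur, 2 chlorine; one six-membered aromatic ring of carbon only) in place of a group of 8 heavy atoms (8 carbon; one six-membered aromatic ring of carbon only), on an amine nitrogen in a ring. For the measured compounds named here, no measured step covers this exact exchange, so the step from compound 1 to compound 4 cannot be read from a direct precedent. What the data do show is that the two thioureas, compounds 2 and 3, give numbers close to each other, and the step between them lies within the scatter. Compound 4 is therefore expected to land in the same region, an estimated 10000 nM with a range from 3000 nM to 40000 nM. That expectation corresponds to a step of an at least 5.0-fold lower number from compound 1 to compound 4 (0.69 log units; beyond the scatter), with the uncertainty that the starting point is itself only a limit.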

Compound 4, half-maximal inhibitory concentration: 3950 nM
For compound 4 the middle estimate is 2.5-fold (0.40 log units) above the measured one; the range from low to high includes it.
By their numbers in this assay, from the lowest: compounds 4, 3 and 2 (each within the scatter of the next, the first and the last beyond it). At a limit, above all of these: compound 1.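

In this assay the exchange of 2-methylbenzyl for the thiourea carrying 2,6-dichlorophenyl on the amine nitrogen in the ring gives an at least 12-fold lower number from compound 1 to compound 4 (1.10 log units; beyond the scatter) and so offers the first direct measure of what a thiourea on this nitrogen does to the number, a large step away from the benzyl substituent. Among these compounds, the size of that step rests on a starting point that is only a limit, and compound 1 remains the one compound at it: the limit of > 50000 nM in this assay, at which 1 of the 4 values shown sits. Among the thioureas, 2,6-dichlorophenyl gives a 1.9-fold lower number from compound 3 to compound 4 (0.28 log units; within the scatter) but also a 3.4-fold lower number from compound 2 to compound 4 (0.53 log units; beyond the scatter) in a modest step, so for the first time an exchange of the aryl group on the amide-type nitrogen moves the number beyond the scatter, though only for one of the two pairs.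

On these data alone, what a urea with oxygen in place of the sulfur would give on the same ring nitrogen stays open, as does the effect of an open-chain alkyl group or a carboxylic acid in place of the aryl group. Compound 1 and compound 4 also differ in the thiourea and the aryl substitution at once, and the compounds shown do not separate the two.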